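Sulfur-linked side chain variants on a shared core

This account rests on a few compounds, and the source may have more. Where it says the series, first, only, none or still open, it means among the compounds named here.

Compound 1, `CC(C)c1n[nH]c2c(NCc3ccc(-c4ccccn4)cc3)nc(SCC(O)CN)nc12`: 55 nM
Compound 2, `CC(C)c1n[nH]c2c(NCc3ccc(-c4ccccn4)cc3)nc(SCC3CNC(=O)O3)nc12`: 80 nM
Compound 3, `CC(C)c1n[nH]c2c(NCc3ccc(-c4ccccn4)cc3)nc(SCCCN(C)C)nc12`: 105 nM

In a functional assay on HT cells (Homo sapiens) for antiproliferative activity, read by fluorescence, with a stated time of 72 h (on this read-out higher numbers stand for weaker inhibition of growth and lower numbers for stronger inhibition of growth), compound 2 gives the second highest of the three numbers. Its nearest neighbour is compound 3, with a 1.3-fold higher number from compound 2 to compound 3 (0.12 log units; within the scatter); its furthest is compound 1, with a 1.5-fold higher number from compound 1 to compound 2 (0.16 log units; within the scatter). All three compounds thus sit within the scatter of one another.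

Compound 4, `CC(C)c1n[nH]c2c(NCc3ccc(-c4ccccn4)cc3)nc(SCCCO)nc12`, differs from compound 2 by 2-hydroxyethyl in place of 2-oxo-1,3-oxazolidin-5-yl on a saturated chain carbon bound to a sulfur. For the measured compounds named here, the steps that bear on this change are those at the same place, a 1.5-fold higher number from compound 1 to compound 2 (0.16 log units; within the scatter) and a 1.3-fold higher number from compound 2 to compound 3 (0.12 log units; within the scatter), both within the scatter. The expectation for compound 4 is therefore no step beyond the scatter, no change at the digits printed from compound 2 to compound 4 (within the scatter). Compound 4 is estimated at 80 nM, within a range from 35 nM to 180 nM.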

Compound 4, concentration for 50% growth inhibition: 109 nM
Estimate against measurement, compound 4: 1.4-fold (0.13 log units) below; low and high end bracket the measured number.
By their numbers in this assay, from the lowest: compounds 1, 2, 3 and 4 (each within the scatter of the next).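

In this assay 2-hydroxyethyl in place of 2-oxo-1,3-oxazolidin-5-yl gives a 1.4-fold higher number from compound 2 to compound 4 (0.13 log units; within the scatter) and hydroxy in place of dimethylamino gives a 1.0-fold higher number from compound 3 to compound 4 (0.02 log units; within the scatter) while 2-hydroxyethyl in place of 2-amino-1-hydroxyethyl gives a 2.0-fold higher number from compound 1 to compound 4 (0.30 log units; within the scatter) and so all three steps stay within the scatter. The side chain of compound 4, with no ring and no nitrogen, thus matches the three earlier side chains within the scatter. Nothing measured here accounts for this.

From the compounds shown here alone, whether a carboxylic acid, a phenyl ring or a longer chain at this place would give a step beyond the scatter remains open.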